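A few compounds are considered here, and "the series" means these few. Any claim that something is new, unique, unknown or untested is made for them only; others in the source may bear on it.

Measured so far in an assay on HEK293 cells for agonist activity at Toll-like receptor 8 (Homo sapiens), read by spectrophotometry; a lower number here means that less compound is needed, a higher number that more compound is needed for the effect:
compound 1, `CCCCCc1c(C)nc(N)nc1NCCCC`: 1220 nM
compound 2, `CCCCNc1nc(N)nc(C)c1CCCN(CC)CC`: 254 nM
compound 3, `CCCCNc1nc(N)nc(C)c1CCC(C)(C)O`: 3140 nM

Compound 3 stands highest of these three numbers: it sits a 2.6-fold higher number from compound 1 to compound 3 (0.41 log units; beyond the scatter) and a 12-fold higher number from compound 2 to compound 3 (1.09 log units; beyond the scatter). Compound 4, `CCCCNc1nc(N)nc(C)c1CCc1ccccc1`, is not yet measured. It differs from compound 3 in one place, (phenyl in place of 1-hydroxy-1-methylethyl on a saturated chain carbon, two bonds along the chain from an aromatic carbon).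

For the measured compounds named here, the steps that bear on this change are those arriving at compound 3. The replacement of propyl by 1-hydroxy-1-methylethyl raised the number, a 2.6-fold higher number from compound 1 to compound 3 (0.41 log units; beyond the scatter), and the replacement of (diethylamino)methyl raised it further, a 12-fold higher number from compound 2 to compound 3 (1.09 log units; beyond the scatter). Replacing 1-hydroxy-1-methylethyl with phenyl is expected to return compound 4 to roughly where compound 1 stands, a modest step down, a 2.6-fold lower number from compound 3 to compound 4 (0.42 log units; beyond the scatter). Compound 4 is therefore estimated at 1200 nM, within 400 nM to 3500 nM.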

Compound 4, half-maximal effective concentration: 1190 nM
Beside the measured number, compound 4's estimate is 1.0-fold (0.00 log units) above it; low and high end bracket the measured number.
By their numbers in this assay, from the lowest: compound 2; then compounds 4 and 1 (each within the scatter of the next); then compound 3.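

In this assay, phenyl in place of 1-hydroxy-1-methylethyl gives a 2.6-fold lower number from compound 3 to compound 4 (0.42 log units; beyond the scatter), so an aromatic ring at this place, carrying no hydrogen-bond donor or acceptor, does not cost activity relative to the hydroxylated group. Phenyl and propyl cannot be told apart here, with a 1.0-fold lower number from compound 1 to compound 4 (0.01 log units; within the scatter), even though only one of them holds a ring. (Diethylamino)methyl remains the group that separates from both, with a 4.7-fold higher number from compound 2 to compound 4 (0.67 log units; beyond the scatter).

No measured evidence accounts for these steps. From the compounds shown here alone, whether a primary amine or a carboxylic acid at this place would follow compound 2 or compound 3 remains open.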